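A Larger Amide on the Sulfur Chain

The source may hold more compounds than are shown below. What is called first, only, known or untested is meant among the compounds shown, and "the series" means these compounds.

- Compound 1 `COc1ccc(-n2c(S)nnc2-c2cc(OC)c(OC)c(OC)c2)cc1` gives > 60000 nM as a limit
- Compound 2 `CCSc1nnc(-c2cc(OC)c(OC)c(OC)c2)n1-c1ccc(OC)cc1` gives 57700 nM as a number
- Compound 3 `CCOC(=O)CSc1nnc(-c2cc(OC)c(OC)c(OC)c2)n1-c1ccc(OC)cc1` gives > 60000 nM as a limit

In a functional assay on PC-3 cells (Homo sapiens) for inhibition, read by MTT assay, with a stated time of 48 h (a lower number here means a stronger inhibitor, a higher number a weaker inhibitor), compound 3 gives > 60000 nM as a limit and not a number. The data around it are thin (the limit of > 60000 nM in this assay, at which 2 of the 3 values shown sit).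

Compound 4 `COc1ccc(NC(=O)CSc2nnc(-c3cc(OC)c(OC)c(OC)c3)n2-c2ccc(OC)cc2)cc1` keeps the shared core, but its ethoxycarbonyl becomes (4-methoxyphenyl)carbamoyl ((4-methoxyphenyl)amino in place of ethoxy on a carbonyl carbon). In plain words, (4-methoxyphenyl)amino takes the place of ethoxy on a carbonyl carbon.

Within the data shown here, three measured steps bear on this change, since each alters the group on the sulfur: (an at least 1.0-fold lower number from compound 1 to compound 2 (0.01 log units; that floor lies within the scatter)), (an at least 1.0-fold higher number from compound 2 to compound 3 (0.01 log units; that floor lies within the scatter)) and (a step that the two limits leave unreadable from compound 1 to compound 3). None of them gives a readable size beyond the scatter, and none involves this exchange, so the size of the coming step remains uncertain.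

Compound 2 at 57700 nM shows that a change on the sulfur can give a number in this assay rather than a limit, so a modest move to a lower number is expected. Compound 4 may still report only a limit. The expected size is an at least 2.4-fold lower number from compound 3 to compound 4 (0.38 log units; beyond the scatter) at the middle of the estimate. The estimated value for compound 4 is 25000 nM with an expected range from 4000 nM to 60000 nM as the upper end.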

Compound 4, half-maximal inhibitory concentration: 25800 nM
Estimate against measurement, compound 4: 1.0-fold (0.01 log units) below; low and high end bracket the measured number.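

In this assay, among these compounds, the exchange of ethoxy for (4-methoxyphenyl)amino on the carbonyl carbon gives the first step on the sulfur chain that lies beyond the scatter, an at least 2.3-fold lower number from compound 3 to compound 4 (0.36 log units; beyond the scatter). Among the compounds shown here, the comparison with compound 2, the only earlier compound with a number rather than a limit, gives a step of full readable size, a 2.2-fold lower number from compound 2 to compound 4 (0.35 log units; beyond the scatter), and the group on the sulfur in compound 1 gives way to the new chain with an at least 2.3-fold lower number from compound 1 to compound 4 (0.36 log units; beyond the scatter). The steps that start at compound 1 and compound 3 are floors and not full sizes, because each of these two compounds reports only a limit: the limit of > 60000 nM in this assay, at which 2 of the 4 values shown sit.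

The compounds shown leave open which part of the (4-methoxyphenyl)amino group goes with the lower number: the amide hydrogen, the six-membered aromatic ring or the methoxy on that ring. A plain methylamino group or a phenylamino group on the same carbonyl carbon, or a carboxylic acid at the end of the chain, would help to separate these parts.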